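Changing One Ring on Compound 2

This account rests on a few compounds, and the source may have more. Where it says the series, first, only, none or still open, it means among the compounds named here.

In a functional assay on DU-145 cells (Homo sapiens) for inhibition, read by trypan blue exclusion, with a stated time of 96 h (a higher number here means a weaker inhibitor of growth, a lower number a stronger inhibitor of growth), compound 1 `Cc1ccc(S(=O)(=O)/C(=C/c2ccc(C)s2)C(=O)c2ccc(Cl)cc2)cc1` gives 50000 nM and compound 2 `COc1ccc(/C=C(\C(=O)c2ccc(Cl)cc2)S(=O)(=O)c2ccc(C)cc2)cc1O` gives 1000 nM as the lower of the two numbers, which makes compound 2 the stronger inhibitor of growth so far. Compound 3 `Cc1ccc(S(=O)(=O)/C(=C/c2ccccc2F)C(=O)c2ccc(Cl)cc2)cc1` differs from compound 2 in one group, with 2-fluorophenyl in place of 3-hydroxy-4-methoxyphenyl on a double-bonded chain carbon bound to a double-bonded chain carbon is the full count. Among the measured compounds shown here, the one measured step bearing on this is a large change of group at that same place (a 50-fold lower number from compound 1 to compound 2 (1.70 log units; beyond the scatter)) and it shows that this place can shift the number strongly. For the measured compounds named here, no measured compound carries 2-fluorophenyl, so the size remains uncertain. A higher number is expected in this assay as the estimated step (an 8.0-fold higher number from compound 2 to compound 3 (0.90 log units; beyond the scatter)) goes beyond the scatter. For compound 3 the estimated value is 8000 nM with an expected range of 1500 nM to 40000 nM for repeated measurements.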

Compound 3, concentration for 50% growth inhibition: 2500 nM
The estimate for compound 3 lay 3.2-fold (0.51 log units) above the measured number, within the range that was stated.
By their numbers in this assay, from the lowest: compound 2; then compound 3; then compound 1.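

In this assay, 2-fluorophenyl costs only a modest step against 3-hydroxy-4-methoxyphenyl (a 2.5-fold higher number from compound 2 to compound 3 (0.40 log units; beyond the scatter)) but gains a large one against 5-methylthiophen-2-yl (a 20-fold lower number from compound 1 to compound 3 (1.30 log units; beyond the scatter)). The group at this place therefore need not hold a hydrogen-bond donor or acceptor for the number to stay far lower than that of compound 1, since 2-fluorophenyl has 0 of each, although compound 2 still keeps a lower number than compound 3. No measurement shown here accounts for these differences between the rings.

Still open, going by these compounds, is how much of the step from compound 2 comes from its hydroxy group and how much from its methoxy group, and whether the fluorine of compound 3 matters at all. A plain phenyl ring or an aminophenyl group at this place could help separate these contributions.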